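A few compounds are considered here, and "the series" means these few. Any claim that something is new, unique, unknown or untested is made for them only; others in the source may bear on it.

In an ADME assay on microsomes from liver (Mus musculus) for metabolic stability, read by LC-MS, with a stated time of 40 min, tested at 0.5 uM (on this read-out higher numbers stand for fast clearance and lower numbers for slow clearance), compound 1 (`CC(C)(CO)S(=O)(=O)c1cccc(NC(=O)c2cccnc2N2CCC3(CC2)CC3)c1`) gives > 399 mL.min-1.g-1, which is a limit and not a number. Compound 3 (`CC(C)(C)NS(=O)(=O)c1cccc(NC(=O)c2ccc(NC(C)(C)CO)cc2N2CCC3(CC2)CC3)n1`) gives > 399 mL.min-1.g-1, also a limit. Among the measured compounds shown here, compound 2 (`CC(C)(C)NS(=O)(=O)c1cccc(NC(=O)c2ccc(NC3(CO)CC3)cc2N2CCC3(CC2)CC3)n1`) is the only one with a number, 58 mL.min-1.g-1.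

Compound 4 (`O=C(Nc1cccc(S(=O)(=O)NC2CC2)c1)c1cccnc1N1CCC2(CC1)CC2`) keeps the core of compound 1 and differs by cyclopropylamino in place of 1-(hydroxymethyl)-1-methylethyl on a sulfonyl sulfur, which turns (1-(hydroxymethyl)-1-methylethyl)sulfonyl into cyclopropylsulfamoyl. For the measured compounds named here, only one measured step offers guidance: an at least 6.8-fold higher number from compound 2 to compound 3 (0.83 log units; beyond the scatter). It puts 1-(hydroxymethyl)-1-methylethyl in place of 1-(hydroxymethyl)cyclopropyl on a nitrogen on an aromatic ring, so it is a different swap in a different place, and it bears on this change only loosely. Read in reverse, it links loss of 1-(hydroxymethyl)-1-methylethyl in favour of a group with a three-membered ring to a lower number. Any reading here is also bounded by the limit of > 399 mL.min-1.g-1 in this assay, at which 2 of the 3 values shown sit.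

The expected step is an at least 1.8-fold lower number from compound 1 to compound 4 (0.25 log units; that floor lies within the scatter), towards slower clearance, and it may remain hidden at the limit. For compound 4 the estimate is 220 mL.min-1.g-1, with an expected range of 70 mL.min-1.g-1 to 399 mL.min-1.g-1.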

Compound 4, intrinsic clearance in microsomes: > 399 mL.min-1.g-1
Compound 4 was reported as a limit; the forecaster's own chance of this, stated with the estimate: 40%; at least 1.8-fold (0.25 log units) between middle value and limit.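

Compound 1 and compound 4 both stand only as limits in this assay, so no step between them can be read: the limit of > 399 mL.min-1.g-1 in this assay, at which 3 of the 4 values shown sit.

The compounds shown leave open how far cyclopropylamino and 1-(hydroxymethyl)-1-methylethyl on a sulfonyl sulfur differ in clearance on the core of compound 1.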